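Swapping benzyl for diisopropylamino on the chain of compound 2

The source may hold more compounds than are shown below. What is called first, only, known or untested is meant among the compounds shown, and "the series" means these compounds.

In an ADME assay on MDBK cells (Bos taurus) for cytotoxicity (on this read-out higher numbers stand for lower toxicity in this test and lower numbers for higher toxicity in this test), compound 1 (`Fc1cccc(F)c1Cn1ccc2nc(-c3ccccc3)nc-2c1`) gives > 100000 nM as a limit of the assay, not a number. Compound 2 (`c1ccc(CCCn2ccc3nc(-c4ccccc4)nc-3c2)cc1`) gives > 100000 nM as a limit too. The record so far is thin: the limit of > 100000 nM in this assay, at which 2 of the 2 values shown sit, is all that can be read. Compound 3 (`CC(C)N(CCn1ccc2nc(-c3ccccc3)nc-2c1)C(C)C`) puts diisopropylamino in place of benzyl on a saturated chain carbon, two bonds along the chain from an aromatic nitrogen. Going by the values given here, the only measured step (a step that the two limits leave unreadable from compound 1 to compound 2) has no readable size, and no measured compound carries diisopropylamino, so the data give no firm guide. A modest move toward a lower number, meaning higher toxicity, is expected only tentatively. The estimated change is an at least 2.5-fold lower number from compound 2 to compound 3 (0.39 log units; beyond the scatter) and the assay may again report only a limit. In this assay compound 3 is expected at 40000 nM with an estimated range from 10000 nM to 100000 nM around that value.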

Compound 3, half-maximal cytotoxic concentration: > 100000 nM
Compound 3: a limit, no number; the forecaster's own chance of this, stated with the estimate: 40%; at least 2.5-fold (0.39 log units) between middle value and limit.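

In this assay, going by these compounds alone, compound 3 also gives only a limit of the assay, not a number, so no step among compound 1, compound 2 and compound 3 can be read. The compounds shown leave open whether changing the group on the chain shifts this read-out at all, and by how much.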